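The source may hold more compounds than are shown below. What is called first, only, known or untested is meant among the compounds shown, and "the series" means these compounds.

Measured compounds in an ADME assay on THP-1 cells (Homo sapiens) for cytotoxicity; on this read-out higher numbers stand for weaker inhibition and lower numbers for stronger inhibition:
- compound 1, `COc1ccc(/C=N/NC(=O)c2ccc(-c3nnc(-c4ccccc4OC)o3)cc2)cc1O`, gives 260000 nM
- compound 2, `COc1ccccc1-c1nnc(-c2ccc(C(=O)N/N=C/c3c(O)cc(O)cc3O)cc2)o1`, gives 12400 nM
- compound 3, `COc1ccccc1-c1nnc(-c2ccc(C(=O)N/N=C/c3cc(O)ccc3O)cc2)o1`, gives 100000 nM

All three share one core and differ only in the aromatic group on a carbon with a double bond to nitrogen. Compound 2 gives the lowest number of the three: the step of an 8.1-fold higher number from compound 2 to compound 3 (0.91 log units; beyond the scatter) and the step of a 21-fold lower number from compound 1 to compound 2 (1.32 log units; beyond the scatter) both lie beyond the scatter, so compound 2 is the strongest inhibitor here.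

Compound 4, `COc1ccccc1-c1nnc(-c2ccc(C(=O)N/N=C/c3ccc(O)c(O)c3)cc2)o1`, is not yet measured. Its change from compound 2 is 3,4-dihydroxyphenyl in place of 2,4,6-trihydroxyphenyl on a carbon with a double bond to nitrogen.

Going by the values given here, two measured steps bear on this. Replacing the 2,4,6-trihydroxyphenyl of compound 2 with a ring carrying fewer oxygen groups gave an 8.1-fold higher number from compound 2 to compound 3 (0.91 log units; beyond the scatter), and compound 1, whose ring also carries two oxygen groups, stands a further a 21-fold lower number from compound 1 to compound 2 (1.32 log units; beyond the scatter) away from compound 2. A move to 3,4-dihydroxyphenyl is therefore expected to raise the number, by a step of about a 9.7-fold higher number from compound 2 to compound 4 (0.99 log units; beyond the scatter). For compound 4 the estimate in this assay is 120000 nM, with a range from 30000 nM to 400000 nM.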

Compound 4, half-maximal inhibitory concentration: 100000 nM
For compound 4 the middle estimate is 1.2-fold (0.08 log units) above the measured one; the measured number falls inside the stated range.
By their numbers in this assay, from the lowest: compound 2; then compounds 3 and 4 (each within the scatter of the next); then compound 1.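

In this assay the move to 3,4-dihydroxyphenyl gave an 8.1-fold higher number from compound 2 to compound 4 (0.91 log units; beyond the scatter) and then no change at the digits printed from compound 3 to compound 4 (within the scatter) so, between these two rings with two hydroxyl groups, where the groups sit made no difference beyond the scatter. The step of a 2.6-fold lower number from compound 1 to compound 4 (0.41 log units; beyond the scatter) isolates a single small change, hydrogen in place of methyl on an oxygen on an aromatic ring, and shows that this change alone moves the number modestly. Nothing shown here explains why any of these rings gives the number it does.

As far as these compounds go, whether the low number of compound 2 follows from how many hydroxyl groups its ring carries or from where they sit remains open. From the compounds shown here alone, what this assay would show for a ring carrying an amine or a carboxylic acid in place of a hydroxyl group is also open.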